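This account rests on a few compounds, and the source may have more. Where it says the series, first, only, none or still open, it means among the compounds named here.

Measured in a functional assay on L1210 cells (Mus musculus) for inhibition; a lower number here means a stronger inhibitor, a higher number a weaker inhibitor:
- compound 1 `C=Cc1cc(O)nc(O)n1`: 3000 nM
- compound 2 `C/C=C/c1cc(O)nc(O)n1`: > 90000 nM (a limit of the assay, not a number)
- compound 3 `C/C=C\c1cc(O)nc(O)n1`: 46000 nM

Compound 2 stands at > 90000 nM, and this value is only a limit. The next step leads to compound 4 `CCOC(=O)/C=C/c1cc(O)nc(O)n1`, which has not yet been measured. The structural change is ethoxycarbonyl in place of methyl on a double-bonded chain carbon bound to a double-bonded chain carbon.

Among the measured compounds shown here, no measured step makes this exact change. The nearest evidence is the pair of large steps for prop-1-en-1-yl in place of vinyl on an aromatic carbon: an at least 30-fold higher number from compound 1 to compound 2 (1.47 log units; beyond the scatter) and a 15-fold higher number from compound 1 to compound 3 (1.19 log units; beyond the scatter). Both moved to higher numbers, so neither compound with a group in place of a vinyl hydrogen kept the value of compound 1. The configuration step, an at least 1.9-fold lower number from compound 2 to compound 3 (0.29 log units; that floor lies within the scatter), has a floor within the scatter. Compound 4 keeps the double bond drawn E, as in compound 2, and its group is larger than methyl.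

No recovery towards compound 1 is therefore assumed, and no step beyond the scatter is expected in this assay. The expected step is a number no higher from compound 2 to compound 4 (the limit leaves the size open). For the measured compounds named here, no measured compound carries ethoxycarbonyl, so the range is kept wide, and a report as a limit is quite possible. For compound 4 the estimated value is 90000 nM, with an expected range of 20000 nM to 300000 nM.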

Compound 4, half-maximal inhibitory concentration: 38000 nM
Beside the measured number, compound 4's estimate is 2.4-fold (0.37 log units) above it; the range from low to high includes it.
By their numbers in this assay, from the lowest: compound 1; then compounds 4 and 3 (each within the scatter of the next). At a limit, above all of these: compound 2.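

In this assay, ethoxycarbonyl in place of methyl on a double-bonded chain carbon bound to a double-bonded chain carbon gives an at least 2.3-fold lower number from compound 2 to compound 4 (0.37 log units; beyond the scatter), so the group carried at this place on the E double bond does change the read-out. Going by these compounds, the value of compound 2, > 90000 nM, is a limit of the assay and not a number, so the step gives only a floor and its full size stays unknown: the limit of > 90000 nM in this assay, at which 1 of the 4 values shown sits. The earlier steps shown here showed only moves to higher numbers on replacing a vinyl hydrogen, whereas this one shows that a larger group here can give a lower number than methyl, although compound 4, at 38000 nM, does not come back to compound 1, at 3000 nM.

The compounds shown do not tell whether the ester as a whole matters or only its carbonyl, a question that a carboxylic acid, a primary amide or a nitrile at the same place would address. Ethoxycarbonyl appears here only on a double bond drawn E, so the result for the Z form of compound 4 remains open.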